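Extending the side chain of compound 3 with an isopropyl group

The source may report more compounds than this note shows. Statements on the series, on what has been measured and on what is new or still open speak of the compounds shown alone.

Of the compounds shown here, three sharing one core have been measured in a physicochemical assay for lipophilicity; a lower number here means a more polar compound, a higher number a more lipophilic compound. Compound 1 `O=C(N[C@@H](CO)C(=O)NO)c1ccc(C#Cc2ccccc2)cc1` gives 2. Compound 2 `CSC[C@H](NC(=O)c1ccc(C#Cc2ccccc2)cc1)C(=O)NO` gives 3. Compound 3 `O=C(CNC(=O)c1ccc(C#Cc2ccccc2)cc1)NO` gives 3, which places it level with compound 2 and, together with it, at the top of the three numbers, while compound 1 sits furthest away, a number 1.00 log units higher from compound 1 to compound 3 (beyond the scatter). The other step onto compound 3 reads no change at the digits printed from compound 2 to compound 3 (within the scatter).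

Compound 4 `CC(C)C(NC(=O)c1ccc(C#Cc2ccccc2)cc1)C(=O)NO` has not yet been measured. It differs from compound 3 in one place: isopropyl in place of hydrogen on a saturated chain carbon bound to an amide-type nitrogen and a carbonyl carbon. The two steps that bear on this are the removal of hydroxymethyl, a number 1.00 log units higher from compound 1 to compound 3 (beyond the scatter), and the removal of (methylsulfanyl)methyl, no change at the digits printed from compound 2 to compound 3 (within the scatter). The entering isopropyl carries no hydrogen-bond donors or acceptors and no net charge, so the step in this assay is expected to run upward, roughly the size of the first of those two steps rather than the flat second one. Compound 4 is therefore estimated at 3.9, with a range from 3.3 to 4.4, an expected step of a number 0.90 log units higher from compound 3 to compound 4 (beyond the scatter).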

Compound 4, distribution coefficient: > 3
Compound 4: no number, only a limit; the forecaster's own chance of this, stated with the estimate: 5%; the middle value lies beyond the limit too.
By their numbers in this assay, from the lowest: compound 1; then compounds 2 and 3 (each within the scatter of the next).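

In this assay compound 4, with isopropyl in place of hydrogen on a saturated chain carbon bound to an amide-type nitrogen and a carbonyl carbon, gives > 3, which is a limit of the assay and not a number: the limit of > 3 in this assay, at which 1 of the 4 values shown sits.

Two steps cannot be read for size: a number no lower from compound 3 to compound 4 (the limit leaves the size open), and a number no lower from compound 2 to compound 4 (the limit leaves the size open). For the compounds shown here, the one step that can be read is a number at least 1.00 log units higher from compound 1 to compound 4 (beyond the scatter). It runs the same way as a number 1.00 log units higher from compound 1 to compound 3 (beyond the scatter) and a number 1.00 log units higher from compound 1 to compound 2 (beyond the scatter).

From the compounds shown here alone, how far compound 4 lies from compound 2 and compound 3 stays open. Also open, going by these compounds, is where an amine, a carboxylic acid or a longer chain on this carbon would fall in this assay.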